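The source may hold more compounds than are shown below. What is called first, only, known or untested is meant among the compounds shown, and "the series" means these compounds.

Series notes. Compound 2 `CC(=O)NCc1ccc(-c2c3ncn(CC4(O)CCN(Cc5ccc(-c6ccco6)cc5Cl)CC4)c(=O)c3nn2C)cc1` gives the lowest number in an assay on isolated protein for inhibition of ubiquitin carboxyl-terminal hydrolase 7 (Homo sapiens), with stated times of 30 min and 2 h (a higher number here means a weaker inhibitor, a lower number a stronger inhibitor), at 46.1 nM. Compound 3 `Cn1nc2c(=O)n(CC3(O)CCN(Cc4ccc(-c5cncs5)cc4Cl)CC3)cnc2c1-c1ccc(CN)cc1` gives 117 nM, and compound 1 `Cn1nc2c(=O)n(CC3(O)CCN(Cc4ccc(-c5ccoc5)cc4Cl)CC3)cnc2c1-c1ccc(CN)cc1` gives 177 nM; both lie beyond the scatter from compound 2. For the measured compounds named here, the one single-point step measured so far is a 1.5-fold lower number from compound 1 to compound 3 (0.18 log units; within the scatter), on a different part of the molecule.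

Compound 4 `Cn1nc2c(=O)n(CC3(O)CCN(Cc4ccc(-c5ccco5)cc4Cl)CC3)cnc2c1-c1ccc(CNC=O)cc1` differs from compound 2 by hydrogen in place of methyl on a carbonyl carbon, acetamidomethyl becoming (formylamino)methyl. Going by the values given here, no measured step touches the carbonyl carbon or its substituent; compound 1 and compound 2 differ in more than one place and show only that their two values are apart. The expectation for compound 4 is therefore a step of a 1.3-fold higher number from compound 2 to compound 4 (0.11 log units; within the scatter), not beyond the scatter. Compound 4 is estimated at 60 nM, within 25 nM to 150 nM.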

Compound 4, half-maximal inhibitory concentration: 20.9 nM
The estimate for compound 4 lay 2.9-fold (0.46 log units) above the measured number; measured number outside the range, below it.
By their numbers in this assay, from the lowest: compound 4; then compound 2; then compounds 3 and 1 (each within the scatter of the next).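

Hydrogen in place of methyl on the carbonyl carbon gives a 2.2-fold lower number from compound 2 to compound 4 (0.34 log units; beyond the scatter) in this assay, the first step read at this place. The methyl of the acetamidomethyl group is therefore not needed for the lower number here, and the (formylamino)methyl group of compound 4 does better than it. Nothing measured here explains the step.

Still open, on these data alone, is how an ethyl group, a longer chain or an amine on the same carbonyl carbon would compare. As far as these compounds go, whether the step holds with the thiazol-5-yl or furan-3-yl groups of the other compounds is also open.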